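Fluoro to Chloro on a Cytotoxicity-Inactive Core

The source may report more compounds than this note shows. Statements on the series, on what has been measured and on what is new or still open speak of the compounds shown alone.

Compound 1, `COc1ccc(/C=C2\CC[C@H]3C(C)(C)CCC[C@]3(C)[C@H]2CCC(C)CC(=O)O)cc1`: > 200000 nM
Compound 2, `CC(CC[C@H]1/C(=C/c2ccc(F)cc2)CC[C@H]2C(C)(C)CCC[C@]12C)CC(=O)O`: > 200000 nM

In a functional assay on THP-1 cells (Homo sapiens) for cytotoxicity, read by MTT assay, with a stated time of 24 h (on this read-out lower numbers stand for stronger inhibition and higher numbers for weaker inhibition), compound 1 gives > 200000 nM, which is a limit of the assay rather than a number. Compound 2 gives > 200000 nM in this assay, again only a limit. Among the measured compounds shown here, the single measured step, a step that the two limits leave unreadable from compound 1 to compound 2, cannot be sized because both values sit at the limit of > 200000 nM in this assay, at which 2 of the 2 values shown sit. Compound 3, `CC(CC[C@H]1/C(=C/c2ccc(Cl)cc2)CC[C@H]2C(C)(C)CCC[C@]12C)CC(=O)O`, remains to be measured; it differs from compound 2 by chloro in place of fluoro on an aromatic carbon. The only measured step bears on this change in kind, a halogen or methoxy swap on the same aromatic carbon, but its size is unreadable, so nothing shown points to a step beyond the scatter. The step from compound 2 to compound 3 is therefore expected to be a number no higher from compound 2 to compound 3 (the limit leaves the size open), meaning none beyond the scatter. Compound 3 is estimated at 200000 nM, with a range from 100000 nM to 500000 nM, most likely reported again as a limit.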

Compound 3, half-maximal inhibitory concentration: > 200000 nM
Compound 3: only a limit was reported (the forecaster's own chance of this, stated with the estimate: 80%); the middle value lies on the limit itself.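

No step can be read among compound 1, compound 2 and compound 3 in this assay, since all three stop at the same limit: the limit of > 200000 nM in this assay, at which 3 of the 3 values shown sit.

Going by these compounds, how far each compound lies from that limit stays open, and so does whether changing 4-fluorophenyl to 4-chlorophenyl makes any difference.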